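Cytotoxicity of a carbamoyl analogue of compound 2

The compounds below may be only part of what the source reports. "The series", "measured", "known", "first", "only" and "open" are said of these compounds alone.

Measured in a functional assay on Ehrlich cells (Mus musculus) for cytotoxicity, read by trypan blue exclusion, with a stated time of 2 h, tested at 50 ug/mL; a lower number here means a weaker effect, a higher number a stronger effect of the compound at the concentration tested:
compound 1, `C=CCNC(=S)NC1=C(C#N)C(c2ccc(Cl)cc2Cl)C2=C(CCCC2=O)N1c1ccc(S(N)(=O)=O)cc1`: 33%
compound 2, `N#CC1=C(NC(=S)Nc2ccc(Br)cc2)N(c2ccc(S(N)(=O)=O)cc2)C2=C(C(=O)CCC2)C1c1ccc(Cl)cc1Cl`: 90%

Compound 2 stands highest of the two numbers; its nearest neighbour is compound 1, and the step between them, a number 57 percentage points higher from compound 1 to compound 2 (beyond the scatter), lies beyond the scatter. Compound 3, `N#CC1=C(NC(N)=O)N(c2ccc(S(N)(=O)=O)cc2)C2=C(C(=O)CCC2)C1c1ccc(Cl)cc1Cl`, has not yet been measured. It differs from compound 2 in one place: a group of 3 heavy atoms (1 carbon, 1 nitrogen, 1 oxygen; no ring) in place of a group of 10 heavy atoms (7 carbon, 1 nitrogen, 1 sulfur, 1 bromine; one six-membered aromatic ring of carbon only), on an amine nitrogen. Among the measured compounds shown here, the only measured step bearing on this position is a number 57 percentage points higher from compound 1 to compound 2 (beyond the scatter), where the 4-bromophenyl group now being removed entered in place of allyl and the number rose strongly. Compound 3 keeps neither group and carries only the small carbamoyl there. Because a number 57 percentage points higher from compound 1 to compound 2 (beyond the scatter) was large, compound 3 is expected to fall well below compound 2, a step of about a number 55 percentage points lower from compound 2 to compound 3 (beyond the scatter). Compound 3 is therefore estimated at 35%, between 15% and 60%.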

Compound 3, a percentage reported as activity, at one concentration (the size of the read-out at that concentration, not a potency): 40%
For compound 3 the middle estimate is 5 percentage points below the measured one; measured number inside the range.
By their numbers in this assay, from the lowest: compounds 1 and 3 (each within the scatter of the next); then compound 2.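

In this assay, a number 50 percentage points lower from compound 2 to compound 3 (beyond the scatter) shows that the high number of compound 2 is lost when carbamoyl replaces the group with the six-membered aromatic ring on this amine nitrogen. The a number 7 percentage points higher from compound 1 to compound 3 (within the scatter) adds that two ringless groups of different size, the carbamoyl of compound 3 and the group carrying the allyl of compound 1, are not told apart here, so among these three compounds only the group carrying the 4-bromophenyl stands out. Nothing measured here gives a reason for this result.

Going by these compounds, it stays open whether the ring alone carries the effect or the bromine contributes, which a plain phenyl or a 4-chlorophenyl in the same place would address. On these data alone, the role of the sulfur also remains open, since the carbamoyl differs from the group it replaces in more than one respect; an oxygen in place of that sulfur, with the 4-bromophenyl kept, would separate the two.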